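The source may hold more compounds than are shown below. What is called first, only, known or untested is meant among the compounds shown, and "the series" means these compounds.

Working notes on the series. Compound 1 `CCOC(=O)[C@H](CC(C)C)N(C(=O)c1ccc(N)cc1)S(=O)(=O)c1ccc(Cn2c(C)nc3cnccc32)cc1` gives 30 nM in a functional assay on the whole organism with Oryctolagus cuniculus as the target; a lower number here means a stronger inhibitor, a higher number a weaker inhibitor. Compound 2 `CCOC[C@H](CC(C)C)N(C(=O)c1ccc(N)cc1)S(=O)(=O)c1ccc(Cn2c(C)nc3cnccc32)cc1` differs from compound 1 by the change ethoxymethyl in place of ethoxycarbonyl on a saturated chain carbon bound to an amide-type nitrogen and a saturated chain carbon and in this assay compound 2 gives 1280 nM. The step is a 43-fold higher number from compound 1 to compound 2 (1.63 log units; beyond the scatter).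

Compound 3 `CCOC(=O)[C@H](CC(C)C)N(Cc1ccc(/N=N\c2ccc(O)c(C(=O)O)c2)cc1)S(=O)(=O)c1ccc(Cn2c(C)nc3cnccc32)cc1` stands on a different core; the difference between the core of compound 1 and the core of compound 3 is not broken down here. In this assay compound 3 gives 490 nM, which sits between the two values above. Compound 4 `CCOC[C@H](CC(C)C)N(Cc1ccc(/N=N\c2ccc(O)c(C(=O)O)c2)cc1)S(=O)(=O)c1ccc(Cn2c(C)nc3cnccc32)cc1` is the unmeasured partner of compound 3, related to it by the change (ethoxymethyl in place of ethoxycarbonyl on a saturated chain carbon bound to a saturated chain carbon and a sulfonamide nitrogen). The groups exchanged are the same as in the first pair, but the surroundings differ: there the carbon is bound to an amide-type nitrogen and a saturated chain carbon, here to a saturated chain carbon and a sulfonamide nitrogen, so this is the same kind of change rather than the same change.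

Within the data shown here, only one measured instance of this exchange exists, and it sits on the other core, so the expectation carries a wide band. Because the measured step of a 43-fold higher number from compound 1 to compound 2 (1.63 log units; beyond the scatter) is large, the step expected here is a 31-fold higher number from compound 3 to compound 4 (1.49 log units; beyond the scatter). On that basis compound 4 is expected to give about 15000 nM in this assay, with an estimated band from 3000 nM to 60000 nM.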

Compound 4, half-maximal inhibitory concentration: 400 nM
Beside the measured number, compound 4's estimate is 38-fold (1.57 log units) above it, and the stated range ends above it.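

In this assay, ethoxymethyl in place of ethoxycarbonyl on the core of compound 3 gives a 1.2-fold lower number from compound 3 to compound 4 (0.09 log units; within the scatter), so on this core the exchange leaves the number within the scatter, in contrast to the large step seen on the core of compound 1. The size of the step therefore does not carry from one core to the other, and the two results differ by more than two such steps would be expected to by chance: the same change on two cores in this assay, a 43-fold higher number (1.63 log units; beyond the scatter) from compound 1 to compound 2 and a 1.2-fold lower number (0.09 log units; within the scatter) from compound 3 to compound 4, 52-fold (1.72 log units) apart, beyond the scatter of two such steps This shows that, within these two pairs, the outcome of the exchange depends on the surrounding core; it does not show which part of the difference between the cores is responsible, why the steps differ, or what the exchange would do on a third core.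

The compounds shown leave open whether the dependence on the core also holds for other replacements of ethoxycarbonyl on the saturated chain carbon, such as hydroxymethyl or a primary amide. They also leave open which single part of the core of compound 3, brought alone into the core of compound 1, would account for the gap between the two steps.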